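Swapping the aryl group on the shared core

A few compounds are considered here, and "the series" means these few. Any claim that something is new, unique, unknown or untested is made for them only; others in the source may bear on it.

Three compounds share one core and differ only in the aryl group on an aromatic nitrogen. Compound 1 `O=C(Nc1ccc(Oc2ccnc3[nH]ccc23)c(F)c1)c1cc2cccnc2n(-c2ccc(F)cc2)c1=O` gives 62 nM in a functional assay on A549 cells (Homo sapiens) for antiproliferative activity, read by MTT assay, with a stated time of 72 h; on this read-out higher numbers stand for weaker inhibition and lower numbers for stronger inhibition; compound 2 `O=C(Nc1ccc(Oc2ccnc3[nH]ccc23)c(F)c1)c1cc2cccnc2n(-c2ccc(Br)cc2)c1=O` gives 210 nM; compound 3 `COc1ccc(-n2c(=O)c(C(=O)Nc3ccc(Oc4ccnc5[nH]ccc45)c(F)c3)cc3cccnc32)cc1` gives 610 nM, the highest number of the three, so the weakest inhibitor here. The steps are a 9.8-fold higher number from compound 1 to compound 3 (0.99 log units; beyond the scatter) and a 2.9-fold higher number from compound 2 to compound 3 (0.46 log units; beyond the scatter), with a 3.4-fold higher number from compound 1 to compound 2 (0.53 log units; beyond the scatter) between the two halogen compounds.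

Compound 4 `O=C(Nc1ccc(Oc2ccnc3[nH]ccc23)c(F)c1)c1cc2cccnc2n(-c2ccc(F)c(Cl)c2)c1=O` is unmeasured; it differs from compound 3 by 3-chloro-4-fluorophenyl in place of 4-methoxyphenyl on an aromatic nitrogen. Both earlier steps that replace the methoxy compound bear on this: moving from a methoxy to a halogen aryl group lowered the number each time, strongly with fluoro in compound 1 and modestly with bromo in compound 2. Compound 4 keeps a fluoro and adds a chloro, so a drop in this assay is expected, most likely landing between compound 1 and compound 2.

For compound 4 the expected value in this assay is 100 nM, within 35 nM to 300 nM, which means an estimated step of a 6.1-fold lower number from compound 3 to compound 4 (0.79 log units; beyond the scatter).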

Compound 4, half-maximal inhibitory concentration: 630 nM
Compound 4: the middle estimate sits 6.3-fold (0.80 log units) below what was measured, outside the stated range (above it).
By their numbers in this assay, from the lowest: compound 1; then compound 2; then compounds 3 and 4 (each within the scatter of the next).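

Until now, a halogen on this aryl group in place of methoxy had lowered the number, but 3-chloro-4-fluorophenyl in place of 4-methoxyphenyl on the aromatic nitrogen gives a 1.0-fold higher number from compound 3 to compound 4 (0.01 log units; within the scatter) in this assay, so a halogen here does not guarantee a gain. The clearest comparison is with compound 1, where a single chloro in place of hydrogen on an aromatic carbon gives a 10-fold higher number from compound 1 to compound 4 (1.01 log units; beyond the scatter), and the comparison with the bromo compound gives a 3.0-fold higher number from compound 2 to compound 4 (0.48 log units; beyond the scatter), which places the new compound level with the methoxy compound rather than with the two compounds carrying one halogen. Nothing available explains this loss.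

The compounds shown leave open how a plain phenyl group would compare on this nitrogen. They also leave open how a phenyl group carrying an amine or a carboxylic acid would behave.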